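Pyrazole Series With Aryl Amide Ends: Growth Inhibition Notes

The source may hold more compounds than are shown below. What is called first, only, known or untested is meant among the compounds shown, and "the series" means these compounds.

Three close analogues sharing one core have been run in a functional assay on SW-620 cells (Homo sapiens) for inhibition, read by sulforhodamine B assay, with a stated time of 48 h; on this read-out higher numbers stand for weaker inhibition of growth and lower numbers for stronger inhibition of growth. Compound 3 `O=C(Nc1cccc(-n2cc(-c3ccncc3)c(-c3ccc(Cl)c(O)c3)n2)c1)Nc1ccc(Cl)c(Cl)c1` carries the 3,4-dichlorophenyl on an amide-type nitrogen and a hydroxy group on the core. In this assay compound 3 reaches only a limit, > 32500 nM. Compound 1 `O=C(Nc1cccc(-n2cc(-c3ccncc3)c(-c3ccc(Cl)c(O)c3)n2)c1)Nc1cccc(C(F)(F)F)c1` differs from compound 3 by 3-(trifluoromethyl)phenyl in place of 3,4-dichlorophenyl on an amide-type nitrogen. In this assay compound 1 likewise stops at a limit, > 32500 nM. The step that the two limits leave unreadable from compound 3 to compound 1 therefore cannot be sized. Compound 2 `COc1cc(-c2nn(-c3cccc(NC(=O)Nc4ccc(Cl)c(Cl)c4)c3)cc2-c2ccncc2)ccc1Cl` differs from compound 3 by methyl in place of hydrogen on an oxygen on an aromatic ring. In this assay compound 2 also gives only a limit, > 50000 nM. The step that the two limits leave unreadable from compound 2 to compound 3 is equally unreadable. Among the measured compounds shown here, two of the three values sit at the limit of > 32500 nM in this assay, at which 2 of the 3 values shown sit, and one at the limit of > 50000 nM in this assay, at which 1 of the 3 values shown sits; the set yields no sized step at all.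

Compound 4 `COc1cc(-c2nn(-c3cccc(NC(=O)Nc4cccc(C(F)(F)F)c4)c3)cc2-c2ccncc2)ccc1Cl` is not yet measured. It differs from compound 2 by 3-(trifluoromethyl)phenyl in place of 3,4-dichlorophenyl on an amide-type nitrogen. The place is the same, word for word, as that of the change from compound 3 to compound 1, so this is the same change, now made on the core of compound 2. That change left both ends at a limit, as a step that the two limits leave unreadable from compound 3 to compound 1 shows, and compound 2 itself stands at the limit of > 50000 nM in this assay, at which 1 of the 3 values shown sits. Compound 4 is therefore expected to show a step of a number no higher from compound 2 to compound 4 (the limit leaves the size open) in this assay. The estimate for compound 4 is 50000 nM, most likely reported again only as a limit, with an expected range from 20000 nM to 120000 nM.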

Compound 4, concentration for total growth inhibition: 14300 nM
Beside the measured number, compound 4's estimate is 3.5-fold (0.54 log units) above it, outside the stated range (below it).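

In this assay, replacing 3,4-dichlorophenyl with 3-(trifluoromethyl)phenyl on the amide-type nitrogen gives an at least 3.4-fold lower number from compound 2 to compound 4 (0.54 log units; beyond the scatter), and with that end in place, methyl in place of hydrogen on the oxygen gives an at least 2.2-fold lower number from compound 1 to compound 4 (0.35 log units; beyond the scatter). Among the compounds shown here, compound 4 is thus the only compound here with a sized value, and it needs both the 3-(trifluoromethyl)phenyl end and the methyl on the oxygen, although both steps start from a limit and their full size stays open. Whether the amide-end change carries from one core to another is not shown, because the matching step from compound 3 to compound 1 cannot be read, and neither can the step from compound 2 to compound 3, since at least one end of each rests on a limit: the limit of > 32500 nM in this assay, at which 2 of the 4 values shown sit.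

The four compounds leave open whether the lower number follows from the trifluoromethyl group itself or from the loss of the two chlorines, and a plain phenyl end or a single chlorine on that ring would help separate the two. They also leave open how far the end can move from these aryl groups, for example to a nitrile or a carboxylic acid on the ring, or to a longer chain in place of the ring.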